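Swapping the charged tail on a chlorinated anilide scaffold

This account rests on a few compounds, and the source may have more. Where it says the series, first, only, none or still open, it means among the compounds named here.

The series is followed in an assay on LX2 cells for inhibition of COL1A1 promoter (Homo sapiens), read by a luciferase reporter, with a stated time of 24 h, tested at 50 uM (on this read-out lower numbers stand for a weaker effect and higher numbers for a stronger effect at the one concentration tested), where compound 1 `Cc1cc(-n2cc(C(=O)Nc3cc(F)cc(F)c3)c(=O)c3ccc(N(C)C)nc32)ccc1OCCCCCCC[N+]12CCN(CC1)CC2` gives 20.8% and compound 3 `Cc1cc(OCCCCCCC[N+](C)(C)C2CCCCC2)cc(-n2cc(C(=O)Nc3cc(F)cc(F)c3)c(=O)c3ccc(N(C)C)nc32)c1` gives 89.1%. Compound 2 `CC[N+]1(CCCCCCCOc2cc(-n3cc(C(=O)Nc4cc(F)cc(F)c4)c(=O)c4ccc(N(C)C)nc43)ccc2Cl)CCCCC1` stands apart from both: in this assay compound 2 returns "not active" (no number reported), so no single number places it on the same scale. The next compound, compound 4 `CN(C)c1ccc2c(=O)c(C(=O)Nc3cc(F)cc(F)c3)cn(-c3ccc(Cl)c(OCCCCCCC[N+](C)(C)C4CCCCC4)c3)c2n1`, keeps the whole of compound 2 apart from its charged tail, where the change is a group of 9 heavy atoms (8 carbon, 1 nitrogen; one six-membered non-aromatic ring of carbon only) in place of a group of 8 heavy atoms (7 carbon, 1 nitrogen; one six-membered non-aromatic ring with 1 hetero atom), on a saturated chain carbon, seven bonds along the chain from an oxygen on an aromatic ring. Among the compounds with values here, the tail that enters is the one carried by compound 3, whose read-out in this assay is 89.1%, while compound 2 with the tail that leaves is reported inactive. Within the data shown here, no measured pair isolates this exchange, so the size of the step is unknown, but the two values suggest a move upward, toward a stronger effect, beyond the scatter. Compound 4 is therefore estimated at 45% in this assay, with a wide range from 10% to 85%.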

Compound 4, a percentage reported as inhibition, at one concentration (the size of the read-out at that concentration, not a potency): 81.4%
Compound 4: the middle estimate sits 36.4 percentage points below what was measured; the range from low to high includes it.
By their numbers in this assay, from the lowest: compound 1; then compounds 4 and 3 (each within the scatter of the next).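

Within the data shown here, with compound 2 reported without a number, no step from it to compound 4 can be read. The compounds shown leave open how large an effect this exchange of charged tail has on its own. No measured property here bears on this result.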